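The source may report more compounds than this note shows. Statements on the series, on what has been measured and on what is new or still open speak of the compounds shown alone.

Working notes on a small series built on one shared core, seen in compound 1, `CC1=C(C(=O)Nc2ccc(F)cc2)C(c2ccc([N+](=O)[O-])cc2)N=C(SCc2ccc(Cl)cc2)N1`. In a functional assay on the whole organism (artery, strain albino) with Rattus norvegicus as the target, with a stated time of 240 min, at a dose of 10 mg/kg by the oral route (on this read-out higher numbers stand for more inhibition at the one dose given (going by the name of the read-out) and lower numbers for less inhibition), compound 1 gives 33.3%. Compound 2, `CC1=C(C(=O)Nc2ccc(F)cc2)C(c2ccc([N+](=O)[O-])cc2)N=C(SCc2ccc(F)cc2)N1`, differs from compound 1 by fluoro in place of chloro on an aromatic carbon. In this assay compound 2 gives 25.6%, and the step reads a number 7.7 percentage points lower from compound 1 to compound 2 (within the scatter). Compound 3, `CC1=C(C(=O)Nc2ccc([N+](=O)[O-])cc2)C(c2ccc(Br)cc2)N=C(SCc2ccc(Cl)cc2)N1`, stands on a different core; the difference between the two cores is not broken down here. In this assay compound 3 gives 29.7%. The numbers of compound 3, compound 1 and compound 2 all sit within the scatter of one another, so no order among the three is drawn.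

Compound 4, `CC1=C(C(=O)Nc2ccc([N+](=O)[O-])cc2)C(c2ccc(Br)cc2)N=C(SCc2ccc(F)cc2)N1`, is not yet measured in this assay. It differs from compound 3 by fluoro in place of chloro on an aromatic carbon, which is the same change as from compound 1 to compound 2, with the place described in the same words for both pairs; the change occurs twice among the compounds shown. Within the data shown here, its one measured instance, a number 7.7 percentage points lower from compound 1 to compound 2 (within the scatter), lies within the scatter, so no real movement is established for it. For compound 4 a step of the same modest size downward is expected, a number 5.7 percentage points lower from compound 3 to compound 4 (within the scatter). Among the measured compounds shown here, that expectation rests only on the single earlier step, a number 7.7 percentage points lower from compound 1 to compound 2 (within the scatter), and carries the full scatter of the read-out. Compound 4 is therefore expected to give 24%, with the estimate placed between 12% and 36%.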

Compound 4, a percentage reported as inhibition, in the whole organism at one dose (the size of the read-out at that dose, not a potency): 27.2%
For compound 4 the middle estimate is 3.2 percentage points below the measured one, and the stated range covers the measured number.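

In this assay the exchange of chloro for fluoro on the benzyl group reads a number 2.5 percentage points lower from compound 3 to compound 4 (within the scatter), so on this second core the step is again small. Set beside the earlier instance, the step shows no difference between the two cores: the same change on two cores in this assay, a number 7.7 percentage points lower (within the scatter) from compound 1 to compound 2 and a number 2.5 percentage points lower (within the scatter) from compound 3 to compound 4, 5.2 percentage points apart, within the scatter of two such steps. This supports treating the exchange of 4-chlorobenzyl for 4-fluorobenzyl as interchangeable within the scatter on these two cores, but it establishes no real lowering, since each step on its own lies within the scatter, and two pairs cannot show that the same would hold on any further core.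

Open, going by these compounds, is whether a group of another kind at this place, such as a methoxy, an amine or a carboxylic acid, or a longer chain in place of the benzyl link to the sulfur, would give a step beyond the scatter in this assay. The compounds shown also leave the difference between the two cores unresolved, as no pair here separates its parts, and with all values taken at a single dose they say nothing about how the inhibition changes with dose.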